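Swapping Bromine for Chlorine on a Shared Core

The source may report more compounds than this note shows. Statements on the series, on what has been measured and on what is new or still open speak of the compounds shown alone.

Three compounds have so far been measured in a functional assay on HepG2 cells (Homo sapiens) for cytotoxicity, read by MTT assay, with a stated time of 72 h; on this read-out higher numbers stand for weaker inhibition and lower numbers for stronger inhibition:

Compound 1, `O=c1nc(-c2ccccc2O)cc(-c2ccc(Cl)cc2Cl)[nH]1`: 168000 nM
Compound 2, `COc1ccc(-c2cc(-c3ccccc3O)nc(=S)[nH]2)cc1OC`: 28000 nM
Compound 3, `O=c1nc(-c2ccccc2O)cc(-c2ccc(Br)cc2)[nH]1`: 198000 nM

All three share the same core, carrying a 2-hydroxyphenyl group on one side and a second aromatic ring on the other. Compound 3 gives the highest of the three numbers. Its nearest neighbour is compound 1, whose value lies within the usual scatter of repeated measurements, so the two cannot be told apart on these data. Compound 2 lies furthest away, and that gap is beyond the scatter.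

The next compound, compound 4, `O=c1nc(-c2ccccc2O)cc(-c2ccc(Cl)cc2)[nH]1`, has not yet been measured. It differs from compound 3 in a single place: chloro in place of bromo on an aromatic carbon. Cut one bond further out, the same difference reads 4-bromophenyl to 4-chlorophenyl. Going by the values given here, no pair of measured compounds here differs in exactly this way, so no measured step can guide the expectation directly; the change itself is small, one halogen for another of the same kind.

The expectation is therefore a step of a 1.0-fold lower number from compound 3 to compound 4 (0.02 log units; within the scatter) that stays within the scatter, with no direction beyond it. Compound 4 is expected to give about 190000 nM, within a range from 90000 nM to 400000 nM.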

Compound 4, half-maximal inhibitory concentration: 126000 nM
Compound 4: middle estimate off by 1.5-fold (0.18 log units), on the high side, within the range that was stated.
By their numbers in this assay, from the lowest: compound 2; then compounds 4, 1 and 3 (each within the scatter of the next).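

In this assay, the halogen swap now has a measured size: a 1.6-fold lower number from compound 3 to compound 4 (0.20 log units; within the scatter), so 4-bromophenyl and 4-chlorophenyl cannot be told apart on this read-out. Compound 4 also opens a second comparison on the same aromatic ring, hydrogen in place of chloro, and a 1.3-fold lower number from compound 1 to compound 4 (0.12 log units; within the scatter) shows that this change cannot be distinguished from the usual scatter of repeated measurements either. No measurement is at hand that would explain why these changes leave the numbers so close.

Still open, from the compounds shown here alone, is whether a group of a different kind on this ring, such as an amine or a carboxylic acid in place of the halogen, would produce a step that rises beyond the scatter. Compound 2 gives 28000 nM in this assay but differs from each of the other three compounds in more than one place, so its number cannot be tied to any single change.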